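Replacing Bromo with Fluoro in Compound 2

The compounds below may be only part of what the source reports. "The series", "measured", "known", "first", "only" and "open" are said of these compounds alone.

Measured so far in a functional assay on HCT-116 cells (Homo sapiens) for inhibition, read by CCK-8 assay, with a stated time of 72 h, tested at 2 uM; a higher number here means more inhibition of growth at the concentration tested, a lower number less inhibition of growth
- compound 1 `COc1ccc(SCc2ccc(C(=O)Nc3ccccc3N)cc2)cc1` gives 73.3%
- compound 2 `Nc1ccccc1NC(=O)c1ccc(CSc2ccc(Br)cc2)cc1` gives 9.96%

Of the two numbers in hand, compound 2 holds the lower one, at 9.96%, and the gap to compound 1 lies beyond the scatter. The next compound to be tested is compound 3 `Nc1ccccc1NC(=O)c1ccc(CSc2ccc(F)cc2)cc1`, which differs from compound 2 by a single exchange: fluoro in place of bromo on an aromatic carbon. This is fluoro in place of bromo on an aromatic carbon, para to a large group.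

For the measured compounds named here, only one measured step bears on this change: a number 63.3 percentage points lower from compound 1 to compound 2 (beyond the scatter). That step is large and replaces one group with another on an aromatic carbon, so a single exchange of this kind can move the number a long way. Going by the values given here, it is also the only evidence available, since no fluoro compound has yet been measured. A rise beyond the scatter is therefore expected, though a moderate one and with much uncertainty.

The expected change is a number 25 percentage points higher from compound 2 to compound 3 (beyond the scatter). In this assay, compound 3 is estimated at 35%, within an expected range of 12% to 65%.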

Compound 3, percent growth inhibition at one concentration: 13.5%
The estimate for compound 3 lay 21.5 percentage points above the measured number; the range from low to high includes it.
By their numbers in this assay, from the lowest: compounds 2 and 3 (each within the scatter of the next); then compound 1.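

In this assay, fluoro in place of bromo on this aromatic carbon gives a number 3.5 percentage points higher from compound 2 to compound 3 (within the scatter), so the two compounds cannot be told apart and the size of the atom swapped in, from bromine to fluorine, leaves no readable mark on the number here. Fluoro in place of methoxy gives a number 59.8 percentage points lower from compound 1 to compound 3 (beyond the scatter), a large step beyond the scatter that stands alongside a number 63.3 percentage points lower from compound 1 to compound 2 (beyond the scatter). The low number of compound 2 is therefore not peculiar to bromo: among the three groups seen on this carbon, only the methoxy of compound 1 goes with a high number. Nothing at hand explains why methoxy stands apart from bromo and fluoro at this position.

As far as these compounds go, it remains open whether the high number belongs to methoxy alone or extends to other groups on this carbon, such as ethoxy, hydroxyl or an amine. The compounds shown also leave open whether methoxy would keep its high number with the sulfur of the shared core exchanged for oxygen.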